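Swapping a halogenated bicycle on the lactone side chain

The compounds below may be only part of what the source reports. "The series", "measured", "known", "first", "only" and "open" are said of these compounds alone.

Compound 1 `COc1nc(OC)c2c(ccn2C/C=C2\OC(=O)C(OCc3ccccc3)=C2OCc2ccccc2)n1` gives 12000 nM in a functional assay on HeLa cells (Homo sapiens) for antiproliferative activity, read by MTT assay, with a stated time of 72 h; on this read-out lower numbers stand for stronger inhibition and higher numbers for weaker inhibition. Compound 2 `O=C1O/C(=C\Cn2cnc3c(F)nc(F)c(Cl)c32)C(OCc2ccccc2)=C1OCc1ccccc1` reaches only the assay limit, > 100000 nM. Compound 3 `O=C1O/C(=C\Cn2cnc3c(Cl)c(F)nc(F)c32)C(OCc2ccccc2)=C1OCc1ccccc1` likewise stops at the limit, > 100000 nM. The step that the two limits leave unreadable from compound 2 to compound 3 cannot be read, as both values sit at the limit of > 100000 nM in this assay, at which 2 of the 3 values shown sit. Within the data shown here, compound 3 thus stands at the limit, without a number of its own, while compound 1 holds the only readable value. Compound 4 `O=C1O/C(=C\Cn2cnc3cc[nH]c3c2=O)C(OCc2ccccc2)=C1OCc1ccccc1` differs from compound 3 by a group of 10 heavy atoms (6 carbon, 3 nitrogen, 1 oxygen; one five-membered aromatic ring with 1 hetero atom, one six-membered aromatic ring with 2 hetero atoms) in place of a group of 12 heavy atoms (6 carbon, 3 nitrogen, 2 fluorine, 1 chlorine; one five-membered aromatic ring with 2 hetero atoms, one six-membered aromatic ring with 1 hetero atom), on a saturated chain carbon bound to a double-bonded chain carbon. Among the measured compounds shown here, no measured step bears on this change; the single step between measured compounds is unreadable, so no direction can be drawn from it. Compound 4 is expected near 30000 nM, between 5000 nM and 150000 nM. The implied step is estimated as an at least 3.3-fold lower number from compound 3 to compound 4 (0.52 log units; beyond the scatter).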

Compound 4, half-maximal inhibitory concentration: 27000 nM
For compound 4 the middle estimate is 1.1-fold (0.05 log units) above the measured one; the measured number falls inside the stated range.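

In this assay, the group on a saturated chain carbon bound to a double-bonded chain carbon now makes a readable difference: replacing the halogenated group gives an at least 3.7-fold lower number from compound 3 to compound 4 (0.56 log units; beyond the scatter) and an at least 3.7-fold lower number from compound 2 to compound 4 (0.56 log units; beyond the scatter). Compound 2 and compound 3 each stop at a limit, so both steps are lower bounds only: the limit of > 100000 nM in this assay, at which 2 of the 4 values shown sit.

The fluorines, the chlorine and the ring pattern all leave at once as a hydrogen-bond donor enters, so the compounds shown cannot say which of these changes counts. Going by these compounds, whether an amine on the same bicycle would lower the number further also stays open.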